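The compounds below may be only part of what the source reports. "The series", "measured", "known", "first", "only" and "open" are said of these compounds alone.

In a functional assay on CCRF-CEM cells (Homo sapiens) for antiproliferative activity (a higher number here means a weaker inhibitor, a lower number a stronger inhibitor), three close relatives have been measured. Compound 1 `COc1cc(C(=O)c2sc(-c3ccc(C)cc3)cc2N)cc(OC)c1OC` gives 15 nM, compound 2 `COc1cc(C(=O)c2sc(-c3ccc(Cl)cc3)cc2N)cc(OC)c1OC` gives 70 nM, and compound 3 `COc1cc(C(=O)c2sc(-c3ccc(C(F)(F)F)cc3)cc2N)cc(OC)c1OC` gives 270 nM. Compound 2 therefore stands second highest of the three: one step is a 4.7-fold higher number from compound 1 to compound 2 (0.67 log units; beyond the scatter), the next is a 3.9-fold higher number from compound 2 to compound 3 (0.59 log units; beyond the scatter), while the full span is an 18-fold higher number from compound 1 to compound 3 (1.26 log units; beyond the scatter).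

Compound 4 `COc1ccc(-c2cc(N)c(C(=O)c3cc(OC)c(OC)c(OC)c3)s2)cc1OC` differs from compound 2 in one place: 3,4-dimethoxyphenyl in place of 4-chlorophenyl on an aromatic carbon

All three measured steps change the group on the same ring that is changed here, and each swaps one small group on that ring for another. They show that this ring is a sensitive place, with a modest to large spread in this assay. None of them, however, brings in a 3,4-dimethoxyphenyl, so they give the size of what a change here can do, not its direction for this particular group. The expectation for compound 4 is a lower number than compound 2, a step of a 2.8-fold lower number from compound 2 to compound 4 (0.45 log units; beyond the scatter), with wide uncertainty. Compound 4 is thus estimated at 25 nM, with a range from 5 nM to 150 nM.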

Compound 4, half-maximal inhibitory concentration: 20 nM
Compound 4: the middle estimate sits 1.3-fold (0.10 log units) above what was measured; the measured number falls inside the stated range.
By their numbers in this assay, from the lowest: compounds 1 and 4 (each within the scatter of the next); then compound 2; then compound 3.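

The 3,4-dimethoxyphenyl group is larger than the 4-chlorophenyl it replaces and adds hydrogen-bond acceptors, yet this position next to the ring sulfur accepts it well: in this assay the change gives a 3.5-fold lower number from compound 2 to compound 4 (0.54 log units; beyond the scatter), and the comparison with the trifluoromethyl compound gives a 14-fold lower number from compound 3 to compound 4 (1.13 log units; beyond the scatter). The step from the 4-methylphenyl compound is a 1.3-fold higher number from compound 1 to compound 4 (0.12 log units; within the scatter), which lies within the scatter, so these two groups cannot be told apart in this assay. Within the data shown here, the earlier steps showed only that numbers rose when the methyl was replaced by chloro or trifluoromethyl, whereas this result shows that a very different and larger group can match the methyl compound, so size alone does not set the number at this position.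

No measurement among these compounds explains why these groups rank as they do. On these data alone, it remains open whether both methoxy groups are needed and how this position would respond to a single methoxy group, an amine or a carboxylic acid on the same phenyl ring.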